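Thiazolyl for dimethylpyrimidinyl on the sulfonamide of compound 1

The source may hold more compounds than are shown below. What is called first, only, known or untested is meant among the compounds shown, and "the series" means these compounds.

For the measured compounds named here, in a functional assay on K562 cells (Homo sapiens) for antiproliferative activity, read by sulforhodamine B assay, with a stated time of 72 h (on this read-out higher numbers stand for weaker inhibition and lower numbers for stronger inhibition), compound 1 `Cc1cc(C)nc(NS(=O)(=O)c2ccc(Nc3nncc4ccccc34)cc2)n1` gives 4.9 nM and holds the lower of the two numbers so far, while compound 2 `S=C(NNc1nncc2ccccc12)Nc1ccccc1` gives 76 nM as the higher number, a gap beyond the scatter. Compound 3 `O=S(=O)(Nc1nccs1)c1ccc(Nc2nncc3ccccc23)cc1` differs from compound 1 by 1,3-thiazol-2-yl in place of 4,6-dimethylpyrimidin-2-yl on a sulfonamide nitrogen and keeps the rest of the structure. Going by the values given here, no measured pair covers this change, so the expectation is loose. A small weakening is expected in this assay, with an estimated 2.0-fold higher number from compound 1 to compound 3 (0.31 log units; beyond the scatter) as the size of the step, close to the scatter. Compound 3 is expected at 10 nM with 3 nM to 35 nM as the estimated range.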

Compound 3, half-maximal inhibitory concentration: 54 nM
The estimate for compound 3 lay 5.4-fold (0.73 log units) below the measured number, outside the stated range (above it).
By their numbers in this assay, from the lowest: compound 1; then compounds 3 and 2 (each within the scatter of the next).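

On a sulfonamide nitrogen, 1,3-thiazol-2-yl in place of 4,6-dimethylpyrimidin-2-yl is a large loss in this assay (an 11-fold higher number from compound 1 to compound 3 (1.04 log units; beyond the scatter)). This position therefore matters to the number: the two aromatic rings are not interchangeable here, and the low value of compound 1 does not carry over to compound 3. Nothing measured here accounts for the loss.

This single pair changes ring size, ring atoms and the two methyl groups together, so it cannot separate them. Unsubstituted pyrimidin-2-yl would separate the methyl groups from the ring, and a morpholine or a plain amine on the sulfonyl sulfur would test whether an aromatic ring is needed at all.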